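Swapping the aryl arm on a fused triazole-thiadiazole core

This account rests on a few compounds, and the source may have more. Where it says the series, first, only, none or still open, it means among the compounds named here.

The series rests on a shared core that carries an aromatic group on one side and a phenyl-terminated chain on the other. Compound 1 `Cc1occc1-c1nnc2sc(CCCc3ccccc3)nn12` gives 17% in an assay for inhibition of histone-lysine N-methyltransferase, H3 lysine-79 specific (Homo sapiens), read by scintillation counting, with stated times of 15 min and 60 min, tested at 50 uM, in the presence of a further agent that is not named here; on this read-out higher numbers stand for a stronger effect at the one concentration tested and lower numbers for a weaker effect. Compound 2 `Fc1cccc(-c2nnc3sc(CCc4ccccc4)nn23)c1` gives 43% in this assay, and that is the higher of the two numbers recorded so far, with compound 1 sitting well below it, beyond the usual scatter. Compound 3 `Cc1occc1-c1nnc2sc(CCc3ccccc3)nn12` has not yet been run. It differs from compound 2 in one place: 2-methylfuran-3-yl in place of 3-fluorophenyl on an aromatic carbon. Among the measured compounds shown here, no measured pair traces this exact change, so the expected size of the step rests on indirect evidence only. A drop in this assay is expected, since compound 1, which also bears a 2-methylfuran-3-yl group, gives 17%. The step from compound 2 to compound 3 is therefore expected to be a number 18 percentage points lower from compound 2 to compound 3 (beyond the scatter), downward and possibly beyond the scatter. For compound 3 the estimated inhibition is 25%, within a range from 5% to 45%.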

Compound 3, a percentage reported as inhibition, at one concentration (the size of the read-out at that concentration, not a potency): 11%
The estimate for compound 3 lay 14 percentage points above the measured number; measured number inside the range.
By their numbers in this assay, from the lowest: compounds 3 and 1 (each within the scatter of the next); then compound 2.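

Among the compounds shown here, this result gives the first measure of a change in one place alone at the aromatic carbon between two ring nitrogen atoms: with the phenyl-terminated chain held constant, 2-methylfuran-3-yl in place of 3-fluorophenyl gives, in this assay, a number 32 percentage points lower from compound 2 to compound 3 (beyond the scatter), a large step. The second single change lies on the chain and not on the aryl arm: with 2-methylfuran-3-yl held constant, phenyl in place of benzyl on a saturated chain carbon gives a number 6 percentage points lower from compound 1 to compound 3 (within the scatter), so this read-out does not separate the two chains when that group is present. Nothing available accounts for the size of the aryl step or for the absence of a resolved chain effect.

For the compounds shown here, it remains open whether the chain change would stay within the scatter with 3-fluorophenyl on the shared core, since the only chain comparison carries 2-methylfuran-3-yl. The aryl swap also replaces the fluorine and the six-membered carbon ring together, so the compounds shown cannot separate those two features, a question that an unsubstituted phenyl or a pyridine ring at the same carbon could address.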